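A few compounds are considered here, and "the series" means these few. Any claim that something is new, unique, unknown or untested is made for them only; others in the source may bear on it.

Of the compounds shown here, three have so far been measured in a physicochemical assay for solubility, read by HPLC, in phosphate buffer, at pH 6.5; a lower number here means a less soluble compound, a higher number a more soluble compound. Compound 1 `COC(=O)C1=C(C)NC(c2nccs2)=NC1(C)c1ccc(Cl)cc1` gives 14 ug/mL, compound 2 `COC(=O)C1=C(C)NC(c2nccs2)=NC1(C)c1ccc(F)c(F)c1` gives 50 ug/mL, and compound 3 `COC(=O)C1=C(CN2CCNCC2)NC(c2nccs2)=NC1(C)c1ccc(F)cc1` gives 250 ug/mL, the highest of the three, clearly ahead of both others. For the measured compounds named here, the only measured step between two compounds differing in a single place, a 3.6-fold higher number from compound 1 to compound 2 (0.55 log units; beyond the scatter), concerns a different part of the shared core and so does not speak directly to the change considered here. Compound 4 `COC(=O)C1=C(Cn2ccnc2)NC(c2nccs2)=NC1(C)c1ccc(F)cc1` differs from compound 3 by 1H-imidazol-1-yl in place of piperazin-1-yl on a saturated chain carbon bound to a double-bonded ring carbon. Going by the values given here, with no measured step covering this change, the expectation rests on compound 3 alone, and a modest move toward the lower values is expected, a 3.6-fold lower number from compound 3 to compound 4 (0.55 log units; beyond the scatter). Compound 4 is accordingly estimated at 70 ug/mL, within a range from 20 ug/mL to 200 ug/mL.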

Compound 4, solubility: 338 ug/mL
The estimate for compound 4 lay 4.8-fold (0.68 log units) below the measured number, and the stated range ends below it.
By their numbers in this assay, from the lowest: compound 1; then compound 2; then compounds 3 and 4 (each within the scatter of the next).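

Replacing piperazin-1-yl with 1H-imidazol-1-yl on a saturated chain carbon bound to a double-bonded ring carbon gives, in this assay, a 1.4-fold higher number from compound 3 to compound 4 (0.13 log units; within the scatter) and so leaves the read-out unresolved between the two groups. Compound 3 alone could not show whether its number required piperazin-1-yl, whereas compound 4 shows that a five-membered aromatic ring in that place reads level with it. Nothing measured here gives a reason for this result. Still open, on these data alone, is whether a morpholine or a dimethylamino group at this position, or a longer chain carrying either group, would read at the same level.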